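This account rests on a few compounds, and the source may have more. Where it says the series, first, only, none or still open, it means among the compounds named here.

Of the compounds shown here, two of a shared core have been tested in a functional assay on the whole organism with Rattus norvegicus as the target, at a dose of 40 mg/kg by the intraperitoneal route; on this read-out higher numbers stand for more inhibition at the one dose given (going by the name of the read-out) and lower numbers for less inhibition. Compound 1, `Cc1nc2c(OCc3ccccc3)ccc(C)n2c1C`, gives 26% in this assay. Compound 2, `CCCc1nc2c(OCc3ccccc3)cccn2c1N`, gives 31% in this assay. For the measured compounds named here, compound 2 is among the two numbers measured so far, and its value and that of compound 1 lie within the usual scatter of each other, so neither can be told apart from the other on these data.

Compound 3, `CC(C)(C)c1nc2c(OCc3ccccc3)cccn2c1N`, has not yet been measured. It differs from compound 2 by tert-butyl in place of propyl on an aromatic carbon. Going by the values given here, no pair of measured compounds shows what such a change does in this assay, so the expected step is a small one, with no clear direction beyond the scatter: a number 1 percentage points lower from compound 2 to compound 3 (within the scatter) is the estimated change from compound 2 to compound 3. Compound 3 is therefore expected to give about 30% in this assay, with a likely range from 10% to 55%.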

Compound 3, a percentage reported as inhibition, in the whole organism at one dose (the size of the read-out at that dose, not a potency): 0%
Estimate against measurement, compound 3: 30 percentage points above, and the stated range ends above it.
By their numbers in this assay, from the lowest: compound 3; then compounds 1 and 2 (each within the scatter of the next).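

Placing tert-butyl in place of propyl on this aromatic carbon, next to the ring atom that bears an amino group, gives a number 31 percentage points lower from compound 2 to compound 3 (beyond the scatter) in this assay. This shows that the position is sensitive to which carbon group it carries, even though both groups contain only carbon and neither has a ring, a hydrogen-bond donor or acceptor, or a net charge. Nothing available explains why this swap has so large an effect.

As far as these compounds go, it remains open whether isopropyl, or a longer chain such as pentyl, would keep the number near that of compound 2 or bring it down towards that of compound 3. Compound 1 differs from both in more than one place, so it cannot settle this.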